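Swapping the aryl for a benzyl on the lactam nitrogen

The source may hold more compounds than are shown below. What is called first, only, known or untested is meant among the compounds shown, and "the series" means these compounds.

Within the data shown here, compound 2 `COc1cccc(N2CC(c3nc(-c4cccc(Cl)c4)no3)CC2=O)c1` gives 690 nM in an in vitro functional assay on HEK293-A cells for negative allosteric modulation of metabotropic glutamate receptor 5 (Homo sapiens), read by FLIPR and calcium flux (on this read-out higher numbers stand for weaker inhibition and lower numbers for stronger inhibition), the only number among the two values shown. Compound 1 `Cc1ccc(N2CC(c3nc(-c4cccc(Cl)c4)no3)CC2=O)cc1C` reaches only the limit of > 10000 nM in this assay, a limit rather than a number (the limit of > 10000 nM in this assay, at which 1 of the 2 values shown sits). The step of an at least 14-fold lower number from compound 1 to compound 2 (1.16 log units; beyond the scatter) shows how much the group on the amide-type nitrogen in a ring matters. Compound 3 `O=C1CC(c2nc(-c3cccc(Cl)c3)no2)CN1Cc1ccc(F)cc1` differs from compound 2 by 4-fluorobenzyl in place of 3-methoxyphenyl on an amide-type nitrogen in a ring. Since that same position carried the large step of an at least 14-fold lower number from compound 1 to compound 2 (1.16 log units; beyond the scatter), a step beyond the scatter is expected, most likely toward weaker inhibition, a 4.3-fold higher number from compound 2 to compound 3 (0.64 log units; beyond the scatter). Compound 3 is therefore estimated at 3000 nM in this assay, between 700 nM and 12000 nM.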

Compound 3, half-maximal inhibitory concentration: 3600 nM
Compound 3: the middle estimate sits 1.2-fold (0.08 log units) below what was measured; low and high end bracket the measured number.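

Replacing 3-methoxyphenyl with 4-fluorobenzyl on the amide-type nitrogen in a ring weakens inhibition in this assay, with a 5.2-fold higher number from compound 2 to compound 3 (0.72 log units; beyond the scatter), yet the benzyl group still outperforms 3,4-dimethylphenyl, with an at least 2.7-fold lower number from compound 1 to compound 3 (0.44 log units; beyond the scatter). Compound 1 stands at a limit and not at a number, so that second step has only a lower bound: the limit of > 10000 nM in this assay, at which 1 of the 3 values shown sits. The three groups now fall in one order at this position: 3-methoxyphenyl, then 4-fluorobenzyl, then 3,4-dimethylphenyl.

The change swaps both the link to the nitrogen and the ring substituent, so the compounds shown cannot separate the two. Going by these compounds, a 3-methoxybenzyl, an unsubstituted benzyl or a longer chain such as 2-phenylethyl would address what remains open.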